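The compounds below may be only part of what the source reports. "The series", "measured", "known", "first", "only" and "open" are said of these compounds alone.

Working notes on the series. Within the data shown here, compound 1 `CCn1c(-c2ccccc2)nc2c(NC3CCC3)ncnc21` and compound 2 `Cn1c(-c2ccc(O)cc2)nc2c(NC3CCCC3)ncnc21` are the two measured members. In an assay on CHO cells for displacement of a labelled ligand from adenosine receptor A3 (Homo sapiens), read by scintillation counting, with a stated time of 3 h (a lower number here means a stronger inhibitor, a higher number a weaker inhibitor), compound 1 gives 84 nM. In this assay compound 2 gives 521 nM, the higher of the two numbers; the gap to compound 1 lies beyond the scatter, but the two differ in more than one place, so no single change can be tied to it.

Compound 3 `Cc1ccc(-c2nc3c(NC4CCCC4)ncnc3n2C)cc1` is unmeasured and differs from compound 2 in one place: methyl in place of hydroxy on an aromatic carbon. Among the measured compounds shown here, nothing among the measured compounds isolates this exchange, so the expected step from compound 2 to compound 3 is small, estimated as a 1.5-fold lower number from compound 2 to compound 3 (0.17 log units; within the scatter), with no clear direction beyond the scatter. For compound 3 in this assay the expected value is 350 nM, estimated to fall between 90 nM and 1300 nM.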

Compound 3, inhibition constant: 480 nM
Beside the measured number, compound 3's estimate is 1.4-fold (0.14 log units) below it, within the range that was stated.
By their numbers in this assay, from the lowest: compound 1; then compounds 3 and 2 (each within the scatter of the next).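

In this assay, among these compounds, the exchange of 4-hydroxyphenyl to 4-methylphenyl gives a 1.1-fold lower number from compound 2 to compound 3 (0.04 log units; within the scatter), and this is the first step that isolates a single place. At this position on the six-membered aromatic ring, para to a large group, hydroxy and methyl cannot be told apart by this number: the hydrogen-bond donor and acceptor counted on the hydroxy leave with no step beyond the scatter. Nothing on hand offers an explanation for this result.

Going by these compounds, whether an amine, a carboxylic acid or a longer chain at this place would move the number beyond the scatter remains open. Compound 1 differs from compound 3 in more than one place, so its number still cannot be tied to any single change.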